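Swapping the Aryl Group on a Shared Amine

The source may hold more compounds than are shown below. What is called first, only, known or untested is meant among the compounds shown, and "the series" means these compounds.

Of the compounds shown here, two of this set have been tested in a functional assay on MCF7 cells (Homo sapiens) for inhibition, read by sulforhodamine B assay; a lower number here means a stronger inhibitor, a higher number a weaker inhibitor. Compound 1 `O=C1C=C(Nc2ccc(I)cc2)C(=O)c2c1nc1n2[C@H]2OC[C@@H](O)[C@H]2OC1` carries a 4-iodophenyl group on its amine nitrogen, and in this assay compound 1 gives 2230 nM. Compound 2 `CCCc1ccc(NC2=CC(=O)c3c(nc4n3[C@H]3OC[C@@H](O)[C@H]3OC4)C2=O)cc1` carries a 4-propylphenyl group in the same place. For compound 2, this assay returns only a limit, > 4000 nM, rather than a number. As far as these compounds go, compound 2 therefore sits at the limit of > 4000 nM in this assay, at which 1 of the 2 values shown sits, so how far beyond that it stands is unknown. Compound 3 `O=C1C(Nc2ccccc2F)=CC(=O)c2c1nc1n2[C@H]2OC[C@@H](O)[C@H]2OC1` is the untested analogue; it differs from compound 2 by 2-fluorophenyl in place of 4-propylphenyl on an amine nitrogen, so that 2-fluorophenyl replaces 4-propylphenyl on the amine nitrogen. Going by the values given here, no measured pair shows what such a change does here; the only guide is that compound 1, which carries a 4-iodophenyl group, gives 2230 nM. The step from compound 2 to compound 3 is expected to be an at least 1.3-fold lower number from compound 2 to compound 3 (0.12 log units; that floor lies within the scatter), a gain beyond the usual scatter. Compound 3 is estimated at 3000 nM, with a likely range from 1000 nM to 10000 nM.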

Compound 3, half-maximal inhibitory concentration: > 4000 nM
Compound 3: no number, only a limit; the forecaster's own chance of this, stated with the estimate: 40%; at least 1.3-fold (0.12 log units) between middle value and limit.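

In this assay compound 3 gives > 4000 nM, which is a limit and not a number. Compound 2 and compound 3 both end at a limit, so no step between them can be read: the limit of > 4000 nM in this assay, at which 2 of the 3 values shown sit.

The compounds shown leave open how far past that limit each one lies, and whether 2-fluorophenyl or 4-propylphenyl gives the lower number.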